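Swapping 3-Fluorophenyl for 4-Fluorophenyl in Compound 1

A few compounds are considered here, and "the series" means these few. Any claim that something is new, unique, unknown or untested is made for them only; others in the source may bear on it.

Among the measured compounds shown here, in a functional assay on HeLa cells (Homo sapiens) for inhibition, read by CCK-8 assay, with a stated time of 72 h, tested at 8 uM (a higher number here means more inhibition of growth at the concentration tested, a lower number less inhibition of growth), compound 1 `Nc1ccccc1NC(=O)/C=C/c1ccc(CSc2cccc(F)c2)cc1` gives 18.6%, the lower of the two numbers so far, well short of compound 2 `COc1ccc(SCc2ccc(C(=O)Nc3ccccc3N)cc2)cc1` at 79.7%. Compound 3 `Nc1ccccc1NC(=O)/C=C/c1ccc(CSc2ccc(F)cc2)cc1` carries 4-fluorophenyl in place of 3-fluorophenyl on a sulfur. For the measured compounds named here, no measured pair yet shows what such a swap does in this assay. The two compounds have the same atoms, joined differently, so only a small upward change, perhaps none beyond the scatter, is expected. The estimated step is a number 5.4 percentage points higher from compound 1 to compound 3 (within the scatter). For compound 3 the expected value is 24%, with a likely range from 8% to 48%.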

Compound 3, percent growth inhibition at one concentration: 10.4%
Beside the measured number, compound 3's estimate is 13.6 percentage points above it, and the stated range covers the measured number.
By their numbers in this assay, from the lowest: compounds 3 and 1 (each within the scatter of the next); then compound 2.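

In this assay, 4-fluorophenyl in place of 3-fluorophenyl on a sulfur gives a number 8.2 percentage points lower from compound 1 to compound 3 (within the scatter) on the shared core. Among the compounds shown here, this is the first measured pair for this swap, and at this place the two fluorophenyl groups cannot be told apart by their growth inhibition. Nothing measured here offers an explanation for this result.

Still open, on these data alone, is whether a plain phenyl or a 4-chlorophenyl on the same sulfur would read any differently. As far as these compounds go, it is also open whether a cyclohexyl group there, with no aromatic ring, would change the reading.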